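Chloro added to the phenyl of compound 2

The compounds below may be only part of what the source reports. "The series", "measured", "known", "first", "only" and "open" are said of these compounds alone.

Of the compounds shown here, two have been measured so far, and their values cannot be ranked. In a functional assay on KM12 cells (Homo sapiens) for inhibition, with a stated time of 48 h (on this read-out lower numbers stand for stronger inhibition of growth and higher numbers for weaker inhibition of growth), compound 2 (`C=CCc1c(O)c(C(=O)/C=C/c2ccccc2)c(OC)c2ccoc12`) gives 4060 nM and compound 1 (`COc1c(C(=O)/C=C/c2ccc(Cl)cc2)c(O)c(Br)c2occc12`) gives 3490 nM as its value, so compound 2 stands within the scatter of compound 1.

The next compound is compound 3 (`C=CCc1c(O)c(C(=O)/C=C/c2ccc(Cl)cc2)c(OC)c2ccoc12`). It departs from compound 2 in one place: chloro in place of hydrogen on an aromatic carbon (chloro in place of hydrogen on an aromatic carbon, para to a large group, so phenyl to 4-chlorophenyl).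

For the measured compounds named here, no measured pair isolates this change. Going by the values given here, compound 1 is the only measured compound carrying 4-chlorophenyl, and its 3490 nM reading offers the sole indication, although it also differs from compound 2 elsewhere on the shared core. That reading lies within the scatter of compound 2, so no step beyond the scatter is expected in this assay for the added chloro. The estimate implies a 1.3-fold lower number from compound 2 to compound 3 (0.10 log units; within the scatter) as an expected shift within the scatter.

For compound 3 the estimated value is 3200 nM as a central figure, with an expected range (1300 nM to 7500 nM).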

Compound 3, concentration for 50% growth inhibition: 3720 nM
Estimate against measurement, compound 3: 1.2-fold (0.07 log units) below; low and high end bracket the measured number.
By their numbers in this assay, from the lowest: compounds 1, 3 and 2 (each within the scatter of the next).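

In this assay, the phenyl to 4-chlorophenyl change can now be read directly on the shared core: chloro in place of hydrogen on an aromatic carbon, para to a large group, gives a step within the scatter (a 1.1-fold lower number from compound 2 to compound 3 (0.04 log units; within the scatter)). The new compound also links the two earlier compounds, since with 4-chlorophenyl held constant, allyl in place of bromo on an aromatic carbon likewise gives a step within the scatter (a 1.1-fold higher number from compound 1 to compound 3 (0.03 log units; within the scatter)), so neither single change separates these compounds on this read-out. No accompanying measurement bears on these two results.

Going by these compounds, each of the two places has so far been read through one replacement only, so it remains open whether an amine or a carboxylic acid on the same aromatic carbon of the phenyl, or a longer chain in place of allyl, would give a step beyond the scatter. Also open, on these data alone, is whether chloro in place of hydrogen gives a similar step when bromo rather than allyl stands on the core.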